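The compounds below may be only part of what the source reports. "The series", "measured", "known", "first", "only" and "open" are said of these compounds alone.

In a functional assay on HCT-15 cells (Homo sapiens) (a lower number here means that less compound is needed, a higher number that more compound is needed for the effect), compound 1 `COc1cc(C2OC(c3ccc(N(C)C)cc3)=NN2C=O)cc(OC)c1OC` gives 0.096 uM, compound 2 `CCOC(=O)C(=O)N1N=C(c2ccc(N(C)C)cc2)OC1c1cc(OC)c(OC)c(OC)c1` gives 45 uM, and compound 3 `COc1cc(C2OC(c3ccc(N(C)C)cc3)=NN2C(=O)COC(C)=O)cc(OC)c1OC` gives 0.019 uM, the lowest of the three. Compound 4 `COc1cc(C2OC(c3ccc(N(C)C)cc3)=NN2C(=O)CN=[N+]=[N-])cc(OC)c1OC` differs from compound 3 in one group: azido in place of acetoxy on a saturated chain carbon bound to a carbonyl carbon. For the measured compounds named here, no measured step makes this exact swap. The nearest evidence is modest, a 5.1-fold lower number from compound 1 to compound 3 (0.70 log units; beyond the scatter), while the other two steps are large, a 470-fold higher number from compound 1 to compound 2 (2.67 log units; beyond the scatter) and a 2400-fold lower number from compound 2 to compound 3 (3.37 log units; beyond the scatter), so this place clearly matters. Compound 4 keeps the saturated chain carbon of compound 3, so a modest rise is expected, a 2.6-fold higher number from compound 3 to compound 4 (0.42 log units; beyond the scatter). For compound 4 the estimated value is 0.05 uM, with an expected range of 0.008 uM to 0.4 uM.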

Compound 4, concentration for half-maximal effect: 0.15 uM
Compound 4: middle estimate off by 3.0-fold (0.48 log units), on the low side; measured number inside the range.
By their numbers in this assay, from the lowest: compound 3; then compounds 1 and 4 (each within the scatter of the next); then compound 2.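

In this assay, azido in place of acetoxy on the saturated chain carbon gives a 7.9-fold higher number from compound 3 to compound 4 (0.90 log units; beyond the scatter) and so the group carried on this carbon matters, not just the presence of the chain carbon. Azidomethyl shows a 300-fold lower number from compound 2 to compound 4 (2.48 log units; beyond the scatter) but also a 1.6-fold higher number from compound 1 to compound 4 (0.19 log units; within the scatter) so it stays far from ethoxycarbonyl yet cannot be told apart from hydrogen on the carbonyl carbon. Nothing available explains why these groups differ. Still open, going by these compounds, is how an amine on this chain carbon, or a longer chain ending in acetoxy, would compare with compound 3.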